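From benzylamino to a bicyclic amine on the sulfonyl sulfur

The source may hold more compounds than are shown below. What is called first, only, known or untested is meant among the compounds shown, and "the series" means these compounds.

Compound 3 `O=C(NCc1ccncc1)Nc1ccc(S(=O)(=O)NCc2ccccc2)cc1` holds the second highest of the three numbers in an assay on isolated protein for activation of Nicotinamide phosphoribosyltransferase (Homo sapiens); on this read-out higher numbers stand for an effect only at larger amounts of compound and lower numbers for an effect already at smaller amounts: compound 3 gives 102 nM, while compound 2 `O=C(NCc1ccncc1)Nc1ccc(S(=O)(=O)c2cccc(Cl)c2)cc1` gives 69 nM and compound 1 `CNS(=O)(=O)c1ccc(NC(=O)NCc2ccncc2)cc1` gives 3230 nM. The nearest step is a 1.5-fold higher number from compound 2 to compound 3 (0.17 log units; within the scatter) and the furthest is a 32-fold lower number from compound 1 to compound 3 (1.50 log units; beyond the scatter). Compound 4 `O=C(NCc1ccncc1)Nc1ccc(S(=O)(=O)N2CC3CCC(C2)O3)cc1` differs from compound 3 in one place: a group of 8 heavy atoms (6 carbon, 1 nitrogen, 1 oxygen; one five-membered non-aromatic ring with 1 hetero atom, one six-membered non-aromatic ring with 2 hetero atoms) in place of a group of 8 heavy atoms (7 carbon, 1 nitrogen; one six-membered aromatic ring of carbon only), on a sulfonyl sulfur. The step that bears most on this is a 32-fold lower number from compound 1 to compound 3 (1.50 log units; beyond the scatter), where methylamino gave way to benzylamino, and a 47-fold lower number from compound 1 to compound 2 (1.67 log units; beyond the scatter) shows the same pattern with 3-chlorophenyl. Going by the values given here, both larger groups on the sulfonyl sulfur gave low numbers, and the entering group of compound 4 matches benzylamino in its count of heavy atoms, yet it brings no aromatic ring and no hydrogen-bond donor, and no measured step covers such a group. The expected step is a 2.9-fold higher number from compound 3 to compound 4 (0.47 log units; beyond the scatter), a modest move toward higher numbers. Compound 4 is therefore estimated at 300 nM, between 80 nM and 1500 nM.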

Compound 4, half-maximal effective concentration: 279 nM
Compound 4: middle estimate off by 1.1-fold (0.03 log units), on the high side; measured number inside the range.
By their numbers in this assay, from the lowest: compounds 2 and 3 (each within the scatter of the next); then compound 4; then compound 1.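

In this assay, compound 4 shows that a bicyclic amine on the sulfonyl sulfur, with no aromatic ring and no hydrogen-bond donor, still retains much of the improvement over methylamino, with a 12-fold lower number from compound 1 to compound 4 (1.06 log units; beyond the scatter). Matching benzylamino in heavy atoms does not match its number, however, as shown by a 2.7-fold higher number from compound 3 to compound 4 (0.44 log units; beyond the scatter), and the 3-chlorophenyl group also gives a lower number, with a 4.0-fold higher number from compound 2 to compound 4 (0.61 log units; beyond the scatter). No measurement of any property of these groups is available to account for these differences.

The compounds shown leave open which feature of benzylamino matters, its aromatic ring or its hydrogen-bond donor. A piperidine, a morpholine or an anilino group on the sulfonyl sulfur would each bear on that question.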